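Amide nitrogen substituent swap: cytotoxicity working notes

The source may report more compounds than this note shows. Statements on the series, on what has been measured and on what is new or still open speak of the compounds shown alone.

compound 1 `O=C(CSc1snnc1-c1ccc(Br)cc1Br)Nc1nccs1`: 87800 nM
compound 2 `O=C(CSc1snnc1-c1ccc(Br)cc1Br)Nc1ccc(Cl)cc1`: 23300 nM

Both numbers come from an ADME assay on MT4 cells (Homo sapiens) for cytotoxicity, read by MTT assay, with a stated time of 5 days; on this read-out lower numbers stand for higher toxicity in this test and higher numbers for lower toxicity in this test. Going by the values given here, compound 2 stands lowest of the two; the only measured step, a 3.8-fold lower number from compound 1 to compound 2 (0.58 log units; beyond the scatter), separates it from compound 1. Compound 3 `COC(=O)c1ccsc1NC(=O)CSc1snnc1-c1ccc(Br)cc1Br` remains to be measured in this assay. The change is 3-(methoxycarbonyl)thiophen-2-yl in place of 4-chlorophenyl on an amide-type nitrogen. Among the compounds with values here, no measured step covers this exchange; the step from compound 1 to compound 2 alters the same nitrogen with different groups, so it offers only a rough scale. A modest upward shift is expected, a 1.9-fold higher number from compound 2 to compound 3 (0.29 log units; within the scatter). Compound 3 is therefore expected near 45000 nM, within 15000 nM to 130000 nM.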

Compound 3, half-maximal cytotoxic concentration: > 227000 nM
Compound 3: no number, only a limit; the forecaster's own chance of this, stated with the estimate: 15%; middle value at least 5.0-fold (0.70 log units) from the limit.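

Compound 3 carries no number, only a limit: the limit of > 227000 nM in this assay, at which 1 of the 3 values shown sits. On the amide-type nitrogen, 3-(methoxycarbonyl)thiophen-2-yl gives an at least 9.7-fold higher number from compound 2 to compound 3 (0.98 log units; beyond the scatter), and in place of 1,3-thiazol-2-yl it gives an at least 2.5-fold higher number from compound 1 to compound 3 (0.41 log units; beyond the scatter). This position therefore spans a wider range than compound 1 and compound 2 showed, and compound 3 stands on the side of lower toxicity in this test relative to both.

As far as these compounds go, how far compound 3 lies past its limit stays open, so neither step has an upper end. Also open, from the compounds shown here alone, is whether the thiophene ring or the methoxycarbonyl group drives the shift; a carboxylic acid or an amine in place of the methoxycarbonyl group would bear on that.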